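The compounds below may be only part of what the source reports. "The series", "measured", "known", "first", "only" and "open" are said of these compounds alone.

Measured in a functional assay on MDA-MB-231 cells (Homo sapiens) for inhibition, read by CCK-8 assay, with a stated time of 48 h; on this read-out higher numbers stand for weaker inhibition of growth and lower numbers for stronger inhibition of growth:
Compound 1 `CN1CCN(c2ccc(Nc3ncc(Cl)c(NCc4ccccc4)n3)nc2)CC1`: 24800 nM
Compound 2 `Cc1ccc(CNc2nc(Nc3ccc(N4CCN(C)CC4)cn3)ncc2Cl)cc1`: 18600 nM

In this assay compound 2 gives 18600 nM. Among the measured compounds shown here, it stands level with the only other measured compound, and the step is small: a 1.3-fold lower number from compound 1 to compound 2 (0.12 log units; within the scatter).

The next compound, compound 3 `CN1CCN(c2ccc(Nc3ncc(Cl)c(NCc4ccc(F)cc4)n3)nc2)CC1`, keeps the shared core and turns 4-methylbenzyl into 4-fluorobenzyl: fluoro in place of methyl on an aromatic carbon. For the measured compounds named here, only one measured step bears on this change, the one that put methyl in place of hydrogen on that same aromatic carbon. It stayed within the scatter, so exchanging this small group has not yet moved the number measurably. Going by the values given here, no compound with fluoro has been measured, so this remains a thin basis. The expected step is a 1.1-fold higher number from compound 2 to compound 3 (0.03 log units; within the scatter), and nothing beyond the scatter is expected. For compound 3 the estimated value is 20000 nM, with an expected range from 9000 nM to 45000 nM.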

Compound 3, concentration for 50% growth inhibition: > 100000 nM
Compound 3 gave a limit, no number (the forecaster's own chance of this, stated with the estimate: 10%); at least 5.0-fold (0.69 log units) between middle value and limit.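

For compound 3 the reading is a limit of the assay, not a number: the limit of > 100000 nM in this assay, at which 1 of the 3 values shown sits. Even so, it shows that this position on the aromatic ring is not indifferent to what sits there: the change of methyl to fluoro gives an at least 5.3-fold higher number from compound 2 to compound 3 (0.73 log units; beyond the scatter), and the change of hydrogen to fluoro gives an at least 4.0-fold higher number from compound 1 to compound 3 (0.60 log units; beyond the scatter), whereas the earlier change of hydrogen to methyl stayed within the scatter. Fluoro therefore stands apart from both hydrogen and methyl here, which the first two compounds could not reveal.

On these data alone, how far compound 3 lies past its limit remains unknown, so the full size of both steps stays open. As far as these compounds go, it is also open whether chloro, methoxy or an amine at this position would behave like fluoro or like methyl.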